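Pentyl in Place of 1-Methylbutyl: An Expected Step

The source may report more compounds than this note shows. Statements on the series, on what has been measured and on what is new or still open speak of the compounds shown alone.

Of the compounds shown here, three sharing one core have been tested in an assay on cells with melanin-concentrating hormone receptor 1 (Homo sapiens) as the target, read by radioligand binding; on this read-out higher numbers stand for weaker inhibition and lower numbers for stronger inhibition. Compound 1 `Nc1ccc2cccc(OCCC(F)(F)F)c2n1` gives 722 nM. Compound 2 `CCCC(C)Oc1cccc2ccc(N)nc12` gives 105 nM, and compound 3 `CC(C)C(C)Oc1cccc2ccc(N)nc12` gives 199 nM. Among these three numbers compound 2 has the lowest, though its gap to compound 3 is within the scatter; only compound 1 stands clearly apart, with a 6.9-fold lower number from compound 1 to compound 2 (0.84 log units; beyond the scatter) and a 3.6-fold lower number from compound 1 to compound 3 (0.56 log units; beyond the scatter). The unmeasured compound 4 `CCCCCOc1cccc2ccc(N)nc12` differs from compound 2 in a single place: pentyl in place of 1-methylbutyl on an oxygen on an aromatic ring. Among the compounds with values here, no measured step exchanges these two particular chains, so the expectation rests on the nearest comparison, a change of the chain on the same oxygen between compound 2 and compound 3: a 1.9-fold higher number from compound 2 to compound 3 (0.28 log units; within the scatter). Because a 1.9-fold higher number from compound 2 to compound 3 (0.28 log units; within the scatter) stayed within the scatter, the step to compound 4 is expected to stay within the scatter too, estimated as a 1.4-fold higher number from compound 2 to compound 4 (0.15 log units; within the scatter). Compound 4 is therefore estimated to give 150 nM in this assay, within an expected range from 60 nM to 400 nM.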

Compound 4, half-maximal inhibitory concentration: 580 nM
Estimate against measurement, compound 4: 3.9-fold (0.59 log units) below; the whole stated range lies below it.
By their numbers in this assay, from the lowest: compounds 2 and 3 (each within the scatter of the next); then compounds 4 and 1 (each within the scatter of the next).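

In this assay the chains on the oxygen hold the same atoms joined differently, yet the unbranched pentyl chain of compound 4 separates clearly from both branched chains: a 5.5-fold higher number from compound 2 to compound 4 (0.74 log units; beyond the scatter) and a 2.9-fold higher number from compound 3 to compound 4 (0.46 log units; beyond the scatter) so the shape of the chain at this position matters, not just its atom count. The two unbranched chains, by contrast, cannot be told apart, with a 1.2-fold lower number from compound 1 to compound 4 (0.10 log units; within the scatter) even though pentyl and 3,3,3-trifluoropropyl differ in their chain ends. Nothing available explains why branching goes with the lower numbers here.

Still open, going by these compounds, is whether isopropyl, a ring such as cyclopentyl or a longer chain on this oxygen would take the number lower than in compound 2. Also open, on these data alone, is whether a branched chain carrying a trifluoromethyl end would follow the same pattern.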